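From 1-hydroxyethyl to hydroxy: a step with little precedent

A few compounds are considered here, and "the series" means these few. Any claim that something is new, unique, unknown or untested is made for them only; others in the source may bear on it.

Compound 1 `CC(=O)CCCCCC/N=C/N1CCC(C(c2ccccc2)c2ccccc2)CC1` (10.5 mg/kg)
Compound 2 `CC(O)CCCCCC/N=C/N1CCC(C(c2ccccc2)c2ccccc2)CC1` (8.9 mg/kg)
Compound 3 `CCCCCCCC/N=C/N1CCC(C(c2ccccc2)c2ccc(O)cc2)CC1` (> 40 mg/kg as a limit of the assay, not a number)

All three compounds were tested in a functional assay on the whole organism (stomach) with Rattus norvegicus as the target (a higher number here means that more compound is needed for the effect, a lower number that less compound is needed), and each value is a dose. Among the measured compounds shown here, compound 2 (8.9 mg/kg) stands level with its only close neighbour, since the step of a 1.2-fold lower number from compound 1 to compound 2 (0.07 log units; within the scatter) lies within the scatter. Compound 3 is reported only as a limit (the limit of > 40 mg/kg in this assay, at which 1 of the 3 values shown sits) and offers no number to compare.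

The unmeasured compound 4 `OCCCCCC/N=C/N1CCC(C(c2ccccc2)c2ccccc2)CC1` carries hydroxy in place of 1-hydroxyethyl on a saturated chain carbon, six bonds along the chain from a double-bonded nitrogen. For the measured compounds named here, the one measured step that bears on this swapped acetyl for 1-hydroxyethyl at that same place, and it stayed within the scatter in this assay as a result. Going by the values given here, that swap kept the carbons that this change removes, and no measured step takes them away, so the guidance is thin. A modest rise in the needed dose is expected, though this direction is only a cautious guess. The estimated change is a 1.6-fold higher number from compound 2 to compound 4 (0.20 log units; within the scatter) and it may prove smaller. For compound 4 the expected value is 14 mg/kg with an estimated range from 6 mg/kg to 35 mg/kg in this measurement.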

Compound 4, dose for half-maximal effect: 11.2 mg/kg
For compound 4 the middle estimate is 1.3-fold (0.10 log units) above the measured one, within the range that was stated.
By their numbers in this assay, from the lowest: compounds 2, 1 and 4 (each within the scatter of the next). At a limit, above all of these: compound 3.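

In this assay the step from 1-hydroxyethyl to hydroxy is a 1.3-fold higher number from compound 2 to compound 4 (0.10 log units; within the scatter) and so the carbons that leave with the 1-hydroxyethyl group make no readable difference at this place. Compared directly with the ketone, the change to hydroxy is a 1.1-fold higher number from compound 1 to compound 4 (0.03 log units; within the scatter) and this places acetyl, 1-hydroxyethyl and hydroxy on this saturated chain carbon all level with one another. The earlier pair showed only that the end of the chain could change its oxygen-bearing group while keeping its carbons, whereas these new steps show, for these three compounds, that the end can also lose carbons without moving the needed dose beyond the scatter.

From the compounds shown here alone, how an amine or a carboxylic acid at this same place would behave remains open, as does the effect of a longer chain carrying the hydroxy group. Why the dose stays so steady across these changes also remains unexplained, as nothing in the data shown speaks to the reason.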